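Aryl oxadiazole nicotinamides: three assay limits and one variation

The compounds below may be only part of what the source reports. "The series", "measured", "known", "first", "only" and "open" are said of these compounds alone.

Measured compounds:
Compound 1, `CC(=O)Nc1ccc(S(=O)(=O)Nc2cccc(-c3nc(-c4ccc(NC(=O)c5cccnc5)cc4Cl)no3)c2)cc1C`: in a functional assay on MDA-MB-231 cells (Homo sapiens) for antiproliferative activity, read by MTT assay, with a stated time of 72 h (on this read-out higher numbers stand for weaker inhibition and lower numbers for stronger inhibition), compound 1 gives > 10000 nM, a limit of the assay.
Compound 2, `CC(=O)Nc1ccc(S(=O)(=O)Nc2cccc(-c3nc(-c4ccc(NC(=O)c5cccnc5)c(C(F)(F)F)c4)no3)c2)cc1`: compound 2 gives > 10000 nM, likewise a limit.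
Compound 3, `O=C(Nc1ccccc1)Nc1cccc(-c2nc(-c3ccc(NC(=O)c4cccnc4)cc3Cl)no2)c1`: compound 3 gives > 10000 nM, again a limit.

Among the measured compounds shown here, compound 3 therefore stands exactly where compounds 1 and 2 stand: every value shown is the assay limit (the limit of > 10000 nM in this assay, at which 3 of the 3 values shown sit), so no ordering among the three can be drawn and no step between compounds differing in a single place is available.

Compound 4, `CC(=O)Nc1ccc(NC(=O)Nc2cccc(-c3nc(-c4ccc(NC(=O)c5cccnc5)cc4Cl)no3)c2)cc1`, differs from compound 3 by one change: acetamido in place of hydrogen on an aromatic carbon. The acetamido enters on an aromatic carbon of a six-membered aromatic ring of carbon only, para to a large group, so that the anilino of compound 3 becomes a (4-acetamidophenyl)amino.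

With nothing but limits to scale from the limit of > 10000 nM in this assay, at which 3 of the 3 values shown sit, the step from compound 3 to compound 4 is expected to be none beyond the scatter, in this assay a step that the limit leaves unreadable from compound 3 to compound 4. Compound 4 is accordingly estimated at 15000 nM, within 5000 nM to 50000 nM, most probably reported only as a limit.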

Compound 4, half-maximal inhibitory concentration: > 10000 nM
Compound 4: only a limit was reported; the forecaster's own chance of this, stated with the estimate: 80%; the middle value does not contradict the limit.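

No step can be read between compound 3 and compound 4 in this assay, because both values are limits: the limit of > 10000 nM in this assay, at which 4 of the 4 values shown sit. The compounds shown leave open how these four compare with one another and which change to the shared core would give a measurable value in this assay.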